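Compound 1 to compound 4: a swap at the limit

The source may hold more compounds than are shown below. What is called first, only, known or untested is meant among the compounds shown, and "the series" means these compounds.

In a functional assay on CFPAC-1 cells (Homo sapiens) for antiproliferative activity, read by MTT assay, with a stated time of 72 h (a lower number here means a stronger inhibitor, a higher number a weaker inhibitor), compound 1 `O=C1O/C(=C\Cn2cc(-c3ccc(Br)cc3)nn2)C(OCc2ccccc2)=C1OCc1ccccc1` gives > 100000 nM, which is a limit of the assay and not a number. Compound 3 `Cc1ccc(-c2cn(C/C=C3\OC(=O)C(OCc4ccccc4)=C3OCc3ccccc3)nn2)cc1` gives > 100000 nM, likewise a limit. Only compound 2 `O=C1O[C@H]([C@@H](O)Cn2cc(-c3ccc(Br)cc3)nn2)C(OCc2ccccc2)=C1OCc1ccccc1` gives a number, 5830 nM. Compound 1 thus stands at the limit of > 100000 nM in this assay, at which 2 of the 3 values shown sit.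

Compound 4 `O=C1O/C(=C\Cn2cc(-c3cc(F)cc(F)c3)nn2)C(OCc2ccccc2)=C1OCc1ccccc1` keeps the shared core and carries 3,5-difluorophenyl in place of 4-bromophenyl on an aromatic carbon. Going by the values given here, the one measured step at that place, a step that the two limits leave unreadable from compound 1 to compound 3, has no readable size, so it gives no measure of what such a change does, and no readable shift in either direction is expected. The expected outcome is a number no higher from compound 1 to compound 4 (the limit leaves the size open). Compound 4 is estimated at 100000 nM, with an expected range from 30000 nM to 300000 nM, and a reading at the limit again is the likeliest result.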

Compound 4, half-maximal inhibitory concentration: "not active" (no number reported)
Compound 4: no number reported; no gap can be computed for the estimate.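

Going by these compounds alone, compound 4 is reported only as "not active", without a number, so no step from compound 1 to it can be read. The compounds shown leave open what 3,5-difluorophenyl in place of 4-bromophenyl does to activity.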